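Working notes: a smaller ring group on the amine nitrogen

The compounds below may be only part of what the source reports. "The series", "measured", "known", "first", "only" and "open" are said of these compounds alone.

Of the compounds shown here, two have been measured in a functional assay on the whole organism (strain Wistar albino) for inhibition, with Rattus norvegicus as the target, read by paw edema, with stated times of 30 min and 2 h, at a dose of 20 mg/kg by the oral route (a higher number here means more inhibition at the dose given (going by the name of the read-out), a lower number less inhibition), so far. Compound 1 `COc1ccccc1NCC(=O)Oc1ccc2c(C)cc(=O)oc2c1` stands lowest of the two numbers: in this assay compound 1 gives 15.3%. Its nearest neighbour is compound 2 `Cc1cc(=O)oc2cc(OC(=O)CNc3cccc([N+](=O)[O-])c3)ccc12`, which in this assay gives 30.7%, a number higher than that of compound 1 by an amount beyond the usual scatter. For the measured compounds named here, no single-place step between compound 1 and compound 2 is available, so the two values are simply what they show.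

Compound 3 `Cc1cc(=O)oc2cc(OC(=O)CNN3C=NNC3)ccc12` is not yet measured. It differs from compound 1 in one place: a group of 5 heavy atoms (2 carbon, 3 nitrogen; one five-membered non-aromatic ring with 3 hetero atoms) in place of a group of 8 heavy atoms (7 carbon, 1 oxygen; one six-membered aromatic ring of carbon only), on an amine nitrogen

Going by the values given here, no measured single-place step exists from which the size of this change could be read, and a change of this kind has no precedent here. The expectation is therefore cautious: a step from compound 1 to compound 3 of a number 9.7 percentage points higher from compound 1 to compound 3 (within the scatter) is expected, most likely upward but possibly not beyond the scatter. For compound 3 the estimate in this assay is 25%, within a range from 10% to 45%.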

Compound 3, a percentage reported as inhibition, in the whole organism at one dose (the size of the read-out at that dose, not a potency): 42.3%
The estimate for compound 3 lay 17.3 percentage points below the measured number; the range from low to high includes it.
By their numbers in this assay, from the lowest: compound 1; then compound 2; then compound 3.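

In this assay, for the compounds shown here, a number 27 percentage points higher from compound 1 to compound 3 (beyond the scatter) is the first single-place step that can be read. On the amine nitrogen, whose other neighbour is a saturated chain carbon, the 2-methoxyphenyl group can give way to a five-membered non-aromatic ring with 3 hetero atoms with a gain in inhibition at the dose given, so for this pair a six-membered aromatic ring of carbon only is not needed at this place. The change alters ring type, heavy-atom count and the counts of hydrogen-bond donors and acceptors all at once, and no measurement available here bears on which of these matters.

The compounds shown leave open whether the gain belongs to this particular ring or would also appear with another group on the same nitrogen, such as an unsubstituted phenyl, a morpholine ring or a short alkyl chain. They also leave open whether a fully aromatic triazole ring at this place would give a number close to that of compound 3 42.3%.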